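Truncating the sulfanyl arm of the shared core

This account rests on a few compounds, and the source may have more. Where it says the series, first, only, none or still open, it means among the compounds named here.

Measured compounds:
compound 1 `Cc1cc(Nc2cc(-c3ccccc3)[nH]n2)n2nc(SCCc3ccccc3)nc2n1` 2700 nM
compound 2 `Cc1cc(Nc2cc(-c3ccccc3)[nH]n2)n2nc(SCC(=O)c3ccccc3)nc2n1` 5240 nM
compound 3 `Cc1cc(Nc2cc(-c3ccccc3)[nH]n2)n2nc(SCc3ccc(Cl)cc3)nc2n1` 8260 nM

In a functional assay on MCF7 cells (Homo sapiens) for inhibition, read by MTT assay, with a stated time of 72 h (a lower number here means a stronger inhibitor, a higher number a weaker inhibitor), compound 3 gives the highest number of the three; its nearest neighbour is compound 2, and the gap from compound 1 to compound 3 is the only one beyond the scatter, as a 3.1-fold higher number from compound 1 to compound 3 (0.49 log units; beyond the scatter) shows. The other two steps, a 1.9-fold higher number from compound 1 to compound 2 (0.29 log units; within the scatter) and a 1.6-fold higher number from compound 2 to compound 3 (0.20 log units; within the scatter), stay within the scatter, so the three sulfanyl arms tried so far give numbers that sit close together.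

Compound 4 `Cc1cc(Nc2cc(-c3ccccc3)[nH]n2)n2ncnc2n1` differs from compound 3 by hydrogen in place of (4-chlorobenzyl)sulfanyl on an aromatic carbon. Within the data shown here, none of the measured steps bears on this change directly: each of them exchanges one group on the saturated chain carbon bound to the sulfur for another, whereas here the whole (4-chlorobenzyl)sulfanyl group is removed and the aromatic carbon carries only hydrogen. The measured steps therefore set no expectation beyond showing that the arm itself is not very sensitive to its substituent.

For compound 4 the number in this assay is estimated at 12000 nM, within 3000 nM to 50000 nM, which means an expected step of a 1.5-fold higher number from compound 3 to compound 4 (0.16 log units; within the scatter).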

Compound 4, half-maximal inhibitory concentration: > 50000 nM
Compound 4: no number, only a limit; the forecaster's own chance of this, stated with the estimate: 20%; middle value at least 4.1-fold (0.61 log units) from the limit.
By their numbers in this assay, from the lowest: compounds 1, 2 and 3 (each within the scatter of the next, the first and the last beyond it). At a limit, above all of these: compound 4.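

In this assay compound 4, with hydrogen on the aromatic carbon in place of the sulfanyl arm, gives only a limit and no number: the limit of > 50000 nM in this assay, at which 1 of the 4 values shown sits.

Removing the arm yields a step beyond the scatter against each of the arm-bearing compounds (an at least 6.0-fold higher number from compound 3 to compound 4 (0.78 log units; beyond the scatter)) and (an at least 9.5-fold higher number from compound 2 to compound 4 (0.97 log units; beyond the scatter)) and (an at least 18-fold higher number from compound 1 to compound 4 (1.26 log units; beyond the scatter)). The earlier steps shown here exchanged one arm for another, while these show that in all three compounds a measurable number goes with having a sulfanyl arm at this carbon.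

As far as these compounds go, how far the number of compound 4 lies past its limit stays open, so the full size of these steps cannot be read. Also open, from the compounds shown here alone, is whether a small methylsulfanyl group, an amine or a longer chain on this carbon would keep a measurable number.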